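This account rests on a few compounds, and the source may have more. Where it says the series, first, only, none or still open, it means among the compounds named here.

Compound 1, `Cc1ccc(-n2nc(-c3ccc(C(F)(F)F)cc3O)nc2-c2ccccc2O)cc1`: 94.1%
Compound 2, `Oc1cc(C(F)(F)F)ccc1-c1nc(-c2ccccc2O)n(-c2ccc(F)cc2)n1`: 86.7%
Compound 3, `Oc1cc(C(F)(F)F)ccc1-c1nc(-c2ccccc2O)n(-c2ccc(Br)cc2)n1`: 89.8%

In a functional assay on PC-12 cells (Rattus norvegicus) for cytotoxicity, read by MTT assay, with stated times of 2 h and 24 h, tested at 5 uM (on this read-out lower numbers stand for a weaker effect and higher numbers for a stronger effect at the one concentration tested), the three measured compounds lie close together. Compound 3 stands second highest of the three numbers; its nearest neighbour is compound 2, with a number 3.1 percentage points higher from compound 2 to compound 3 (within the scatter), and its furthest is compound 1, with a number 4.3 percentage points lower from compound 1 to compound 3 (within the scatter). Compound 4, `COc1ccc(-n2nc(-c3ccc(C(F)(F)F)cc3O)nc2-c2ccccc2O)cc1`, differs from compound 3 by methoxy in place of bromo on an aromatic carbon. The measured steps that bear on this change are those in which a group on an aromatic carbon of the shared core was exchanged: a number 7.4 percentage points lower from compound 1 to compound 2 (within the scatter), a number 4.3 percentage points lower from compound 1 to compound 3 (within the scatter) and a number 3.1 percentage points higher from compound 2 to compound 3 (within the scatter). None of them left the scatter, so the read-out has not yet responded to any exchange at that carbon. A methoxy group has not been measured there, but the available steps give no ground to expect a different outcome. Compound 4 is therefore expected to show a number 0.8 percentage points lower from compound 3 to compound 4 (within the scatter), that is, no step beyond the scatter. The estimate for compound 4 in this assay is 89%, with a range from 77% to 98%.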

Compound 4, a percentage reported as activity, at one concentration (the size of the read-out at that concentration, not a potency): 86.6%
Compound 4: middle estimate off by 2.4 percentage points, on the high side, within the range that was stated.
By their numbers in this assay, from the lowest: compounds 4, 2, 3 and 1 (each within the scatter of the next).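

Methoxy in place of bromo gives a number 3.2 percentage points lower from compound 3 to compound 4 (within the scatter) and, set against the other two groups at this carbon, a number 0.1 percentage points lower from compound 2 to compound 4 (within the scatter) and also a number 7.5 percentage points lower from compound 1 to compound 4 (within the scatter) in this assay at the one concentration tested. The earlier steps shown here covered methyl, fluoro and bromo, and this result adds a group with one more heavy atom than bromo and a hydrogen-bond acceptor, on an aromatic carbon para to a large group, with the read-out still inside the scatter. Nothing given here accounts for this flat response.

Going by these compounds, whether an amine or a carboxylic acid at this carbon would carry the read-out beyond the scatter remains open. So does whether these four compounds would separate at a lower concentration.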